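A few compounds are considered here, and "the series" means these few. Any claim that something is new, unique, unknown or untested is made for them only; others in the source may bear on it.

Measured in a functional assay on Caco-2 cells (Homo sapiens) for antiproliferative activity, read by MTT assay; a lower number here means a stronger inhibitor, a higher number a weaker inhibitor:
Compound 1, `NS(=O)(=O)c1cccc(/N=C2\NC(=O)/C(=C3/C(=O)Nc4ccc(Br)cc43)S2)c1`: 10800 nM
Compound 2, `Cc1cc(C)c2c(c1)/C(=C1/S/C(=N/c3ccc(S(N)(=O)=O)cc3)NC1=O)C(=O)N2`: 146000 nM

Of these two numbers, compound 1 holds the lower one. Compound 2 stands at 146000 nM, a gap that lies beyond the usual scatter of repeated measurements, so compound 1 is the stronger inhibitor of the pair. Among the compounds with values here, no pair of measured compounds differing in only one place is available here, so no measured step can serve as a direct guide for the move to compound 3.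

Compound 3, `NS(=O)(=O)c1cccc(/N=C2\NC(=O)/C(=C3/C(=O)Nc4ccc(Cl)cc43)S2)c1`, differs from compound 1 in a single place: chloro in place of bromo on an aromatic carbon. The shared core is otherwise unchanged. Within the data shown here, with no measured step of this kind to lean on, the expectation is that the exchange leaves the number close to where compound 1 stands, within the scatter, perhaps a shade toward the weaker side. Compound 3 is therefore expected to give about 14000 nM in this assay, with a range from 5000 nM to 40000 nM, which corresponds to an expected step of a 1.3-fold higher number from compound 1 to compound 3 (0.11 log units; within the scatter).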

Compound 3, half-maximal inhibitory concentration: 5870 nM
Estimate against measurement, compound 3: 2.4-fold (0.38 log units) above; measured number inside the range.
By their numbers in this assay, from the lowest: compounds 3 and 1 (each within the scatter of the next); then compound 2.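

Within the data shown here, the step from bromo to chloro is the first single-place change in this set, and it gives the position its first direct reading: in this assay, the exchange on this aromatic carbon, part of a fused system of two rings, amounts to a 1.8-fold lower number from compound 1 to compound 3 (0.26 log units; within the scatter). Compound 1 and compound 3 therefore cannot be told apart in this assay, and at this position one of these halogens serves as well as the other, a point that the earlier comparison of compound 1 with compound 2, which differ in more than one place, could not show. Nothing available here accounts for the size of this step or bears on the result.

From the compounds shown here alone, the step covers only two halogens, so it remains open how this carbon would respond to fluoro, to a methoxy group, to an amine or to a nitrile, or to plain hydrogen in place of the halogen. Going by these compounds, it is also open whether the same exchange would read alike with the sulfonamide-bearing ring of compound 2, whose number cannot be traced to any single place.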